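A few compounds are considered here, and "the series" means these few. Any claim that something is new, unique, unknown or untested is made for them only; others in the source may bear on it.

Compound 1 `CCCS(=O)(=O)Nc1cccc2c1CCC2c1ncc[nH]1` – in a functional assay on CHO cells for agonist activity at Alpha-1A adrenergic receptor (Homo sapiens), read by FLIPR and calcium flux (on this read-out higher numbers stand for an effect only at larger amounts of compound and lower numbers for an effect already at smaller amounts), compound 1 gives 1340 nM.
Compound 2 `Cn1ccc(-c2cccc3c2CCC3c2ncc[nH]2)n1` – in this assay compound 2 gives > 1300 nM; this is a limit of the assay, not a number.
Compound 3 `COc1cccc2c1CCC2c1ncc[nH]1` – in this assay compound 3 gives 32 nM.

Compound 3 holds the lowest of the two numbers shown; the nearest is compound 1, and the step from compound 1 to compound 3 is a 42-fold lower number from compound 1 to compound 3 (1.62 log units; beyond the scatter). The third value, that of compound 2, is a limit (the limit of > 1300 nM in this assay, at which 1 of the 3 values shown sits).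

Compound 4 `Cn1nccc1-c1cccc2c1CCC2c1ncc[nH]1` has not yet been measured. It differs from compound 3 in one place: 1-methyl-1H-pyrazol-5-yl in place of methoxy on an aromatic carbon. Among the compounds with values here, two measured steps bear on this. From compound 2 to compound 3 the step is an at least 40-fold lower number from compound 2 to compound 3 (1.60 log units; beyond the scatter), where a 1-methyl-1H-pyrazol-3-yl gives way to methoxy. From compound 1 to compound 3 the step is a 42-fold lower number from compound 1 to compound 3 (1.62 log units; beyond the scatter), where (propylsulfonyl)amino gives way to methoxy. Both larger groups in that place go with a much higher number than methoxy. Compound 4 places a pyrazole of another attachment in the same position, so a large step upward in this assay is expected, estimated as a 31-fold higher number from compound 3 to compound 4 (1.49 log units; beyond the scatter). For compound 4 in this assay the value is expected to be about 1000 nM, in the range 200 nM to 4000 nM, with a real chance that only a limit is reported.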

Compound 4, half-maximal effective concentration: 278 nM
For compound 4 the middle estimate is 3.6-fold (0.56 log units) above the measured one; the range from low to high includes it.
By their numbers in this assay, from the lowest: compound 3; then compound 4; then compound 1.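

Moving the point of attachment of the pyrazole matters in this place on the aromatic carbon: in this assay, 1-methyl-1H-pyrazol-5-yl in place of 1-methyl-1H-pyrazol-3-yl gives an at least 4.6-fold lower number from compound 2 to compound 4 (0.66 log units; beyond the scatter), although the two groups are made of the same atoms. The value of compound 2 is a limit, not a number: the limit of > 1300 nM in this assay, at which 1 of the 4 values shown sits. The earlier compounds shown here had linked both larger groups with a much higher number than methoxy, but the size of that rise now proves to depend on the group, with an 8.7-fold higher number from compound 3 to compound 4 (0.94 log units; beyond the scatter) for this pyrazole and a 4.8-fold lower number from compound 1 to compound 4 (0.68 log units; beyond the scatter) against (propylsulfonyl)amino, while methoxy still holds the lowest number of the series.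

The compounds shown leave open whether the methyl on the pyrazole contributes to this difference, since every pyrazole here carries one, and how a pyrazole without it would compare. They also leave open whether a hydroxyl, a primary amine or an ethoxy chain in the same place would fall below or above the number of compound 3.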